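Working notes: a propargyl step repeated on a second core

The compounds below may be only part of what the source reports. "The series", "measured", "known", "first", "only" and "open" are said of these compounds alone.

Measured so far in an assay on isolated protein for inhibition of Amine oxidase [flavin-containing] A (Homo sapiens), read by fluorescence, with stated times of 10 min, 10 s and 20 min; on this read-out higher numbers stand for weaker inhibition and lower numbers for stronger inhibition:

Compound 1 `CCN(CC)C(=O)Nc1ccc2[nH]ccc2c1`; compound 1 gives > 100000 nM, which is a limit of the assay and not a number.
Compound 2 `CCN(CC)C(=O)Oc1ccc2cc[nH]c2c1`; compound 2 gives 88100 nM.
Compound 3 `C#CCn1ccc2cc(NC(=O)N(CC)CC)ccc21`; compound 3 gives 33400 nM.

Compound 3 is compound 1 with one change, (propargyl in place of hydrogen on an aromatic nitrogen). The step it made is an at least 2.9-fold lower number from compound 1 to compound 3 (0.47 log units; beyond the scatter). The value of compound 1 sits at the limit of > 100000 nM in this assay, at which 1 of the 3 values shown sits, so the true size of that step is open at the upper end and may be larger than the figure given.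

Compound 2 has a different core from compound 1; the difference between the two cores is not broken down here. Among the numbers so far, compound 2 carries the highest one, and compound 3 is the nearest to it, with a lower number that lies beyond the scatter.

The unmeasured compound is compound 4 `C#CCn1ccc2ccc(OC(=O)N(CC)CC)cc21`. Among the compounds with values here, it differs from compound 2 by propargyl in place of hydrogen on an aromatic nitrogen, the same change as the one from compound 1 to compound 3, at a place described in the same words. The expectation for the step from compound 2 to compound 4 is therefore set beside the earlier one: an estimated 3.5-fold lower number from compound 2 to compound 4 (0.55 log units; beyond the scatter), resting on compound 1 and compound 3 having shown an at least 2.9-fold lower number from compound 1 to compound 3 (0.47 log units; beyond the scatter). Because compound 1 stands at the limit of > 100000 nM in this assay, at which 1 of the 3 values shown sits, the earlier step could exceed its stated size, so the range for compound 4 is kept wide. Compound 4 is expected to give 25000 nM, between 8000 nM and 70000 nM, in this assay.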

Compound 4, half-maximal inhibitory concentration: 51600 nM
Estimate against measurement, compound 4: 2.1-fold (0.31 log units) below; measured number inside the range.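

On the core of compound 2, propargyl in place of hydrogen on an aromatic nitrogen gives a 1.7-fold lower number from compound 2 to compound 4 (0.23 log units; within the scatter) in this assay, so on this core the change cannot be told apart from the usual spread of repeated measurements. The two pairs therefore do not show that the step carries over from one core to the other with the same size, and they do not show that its size depends on the core either: the same change on two cores in this assay, an at least 2.9-fold lower number (0.47 log units; beyond the scatter) from compound 1 to compound 3 and a 1.7-fold lower number (0.23 log units; within the scatter) from compound 2 to compound 4; the limit leaves it open whether they differ
Within the data shown here, compound 1 gives > 100000 nM, which is a limit of the assay and not a number, so the size of the first step stays open at its upper end and only one of the two steps is printed as beyond the scatter.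

The compounds shown leave open whether the triple bond itself matters, since a saturated propyl chain, a methyl or a longer chain on the same aromatic nitrogen would be needed to separate it from the mere presence of a substituent there. They also leave open whether the two cores would respond alike to a group carrying an amine or a carboxylic acid at that nitrogen, and how the cores themselves compare, since they differ in more than one place.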